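Inverting One Stereocentre of Compound 2

A few compounds are considered here, and "the series" means these few. Any claim that something is new, unique, unknown or untested is made for them only; others in the source may bear on it.

In a functional assay on Hs 683 cells (Homo sapiens) for inhibition, read by colorimetric assay and MTT assay, with a stated time of 72 h (on this read-out higher numbers stand for weaker inhibition and lower numbers for stronger inhibition), three compounds on a shared core differ in the group on a saturated chain carbon. Compound 1 `C/C1=C\CC[C@@]2(C)O[C@@H]2[C@H]2OC(=O)[C@@H](CN3CCCC3)[C@@H]2C[C@H]1O`, with pyrrolidin-1-yl, gives 15000 nM. Compound 2 `C/C1=C\CC[C@@]2(C)O[C@@H]2[C@H]2OC(=O)[C@@H](CN3CCCCC3)[C@@H]2C[C@H]1O`, with piperidin-1-yl, gives 7000 nM. Compound 3 `C/C1=C\CC[C@@]2(C)O[C@@H]2[C@H]2OC(=O)[C@@H](CN3CCN(C)CC3)[C@@H]2C[C@H]1O`, with 4-methylpiperazin-1-yl, gives 33000 nM. Compound 2 therefore has the lowest number of the three, and both of its steps lie beyond the scatter: a 2.1-fold lower number from compound 1 to compound 2 (0.33 log units; beyond the scatter) and a 4.7-fold higher number from compound 2 to compound 3 (0.67 log units; beyond the scatter).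

Compound 4 `C/C1=C\CC[C@@]2(C)O[C@@H]2[C@H]2OC(=O)[C@@H](CN3CCCCC3)[C@@H]2C[C@@H]1O` keeps the piperidin-1-yl group of compound 2 and departs from it in configuration only: the two compounds have the same atoms and bonds and differ only in configuration as drawn: 1 of 7 stereo elements differ; a stereocentre at a saturated ring carbon is drawn R in compound 2 and S in compound 4. For the measured compounds named here, no measured step inverts a stereocentre, so the data offer no direct precedent. The group swaps bear on it only indirectly, by showing how far the numbers move within this series, with a 2.2-fold higher number from compound 1 to compound 3 (0.34 log units; beyond the scatter) as a further modest example. A small step is expected, no larger than these and quite possibly within the scatter. Its expected direction is upward because compound 2 already stands lowest at 7000 nM. The estimated step is a 1.7-fold higher number from compound 2 to compound 4 (0.23 log units; within the scatter). Compound 4 is expected at about 12000 nM, with an estimated range from 4500 nM to 30000 nM.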

Compound 4, half-maximal inhibitory concentration: 7000 nM
The estimate for compound 4 lay 1.7-fold (0.23 log units) above the measured number, and the stated range covers the measured number.
By their numbers in this assay, from the lowest: compounds 2 and 4 (each within the scatter of the next); then compound 1; then compound 3.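

In this assay, the first inversion in this series, at a saturated ring carbon drawn R in compound 2 and S in compound 4, comes out as no change at the digits printed from compound 2 to compound 4 (within the scatter). For the compounds shown here, the earlier compounds showed only that the number moves with the group on the saturated chain carbon, as in a 4.7-fold higher number from compound 2 to compound 3 (0.67 log units; beyond the scatter), and they said nothing about configuration; with piperidin-1-yl in place, this stereocentre can be drawn either way with no step beyond the scatter. The comparison speaks to this stereocentre alone, because nothing else separates the pair: the fact that compounds 2 and 4 differ only in the configuration as drawn

The compounds shown leave open whether the same inversion would also leave the number within the scatter with the pyrrolidin-1-yl group of compound 1 or the 4-methylpiperazin-1-yl group of compound 3, and whether inverting any other stereocentre of the shared core would do the same. Also open, from the compounds shown here alone, is where a morpholin-4-yl or dimethylamino group on the saturated chain carbon would stand in either configuration.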